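Growth inhibition notes: compound 3 to compound 4

This account rests on a few compounds, and the source may have more. Where it says the series, first, only, none or still open, it means among the compounds named here.

In a functional assay on PC-3 cells (Homo sapiens) for inhibition, read by sulforhodamine B assay, with a stated time of 48 h, tested at 50 uM (on this read-out lower numbers stand for less inhibition of growth and higher numbers for more inhibition of growth at the one concentration tested), compound 1 `COc1cc(/C=C/C(=O)/C=C/c2cccc3ccccc23)ccc1OCc1cn(CCOc2cc(=O)oc3ccccc23)nn1` gives 20%, compound 2 `COc1cccc(/C=C/C(=O)/C=C/c2ccc(OCc3cn(CCOc4cc(=O)oc5ccccc45)nn3)c(OC)c2)c1` gives 13% and compound 3 `COc1ccc(/C=C/C(=O)/C=C/c2ccc(OCc3cn(CCOc4cc(=O)oc5ccccc45)nn3)c(OC)c2)cc1OC` gives 19%. Compound 3 thus lies within the scatter of both other compounds, and the three form one low group. Compound 4 `COc1cc(/C=C/C(=O)/C=C/c2ccccc2)ccc1OCc1cn(CCOc2cc(=O)oc3ccccc23)nn1` differs from compound 3 as follows: phenyl in place of 3,4-dimethoxyphenyl on a double-bonded chain carbon bound to a double-bonded chain carbon. This places phenyl in place of 3,4-dimethoxyphenyl on a double-bonded chain carbon bound to a double-bonded chain carbon. Methoxy in place of hydrogen on an aromatic carbon gave a number 6 percentage points higher from compound 2 to compound 3 (within the scatter). Replacing naphthalen-1-yl gave a number 7 percentage points lower from compound 1 to compound 2 (within the scatter) and a number 1 percentage points lower from compound 1 to compound 3 (within the scatter). No shift beyond the scatter is therefore expected, and the expected step is a number 3 percentage points lower from compound 3 to compound 4 (within the scatter). The estimate for compound 4 is 16%, with an expected range of 6% to 28%.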

Compound 4, percent growth inhibition at one concentration: 10%
Beside the measured number, compound 4's estimate is 6 percentage points above it, within the range that was stated.
By their numbers in this assay, from the lowest: compounds 4, 2, 3 and 1 (each within the scatter of the next).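

In this assay the change to phenyl on a double-bonded chain carbon bound to a double-bonded chain carbon stays within the scatter whichever group it replaces, with a number 9 percentage points lower from compound 3 to compound 4 (within the scatter) and a number 3 percentage points lower from compound 2 to compound 4 (within the scatter) and a number 10 percentage points lower from compound 1 to compound 4 (within the scatter) as its readings. Even with no methoxy left on this ring, compound 4 stays in the one low group, and none of the four groups at this position separates from another. No measured evidence bears on this result.

From the compounds shown here alone, whether an amine, a carboxylic acid or a longer chain at this position would move the number beyond the scatter remains open.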